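This account rests on a few compounds, and the source may have more. Where it says the series, first, only, none or still open, it means among the compounds named here.

Compound 3 `COC(=O)N1CCN(CCN2CCC(CNC(=O)c3cccc4[nH]c(C(C)C)nc34)CC2)CC1` stands second highest of the three measured compounds in a functional assay for agonist activity at 5-hydroxytryptamine receptor 4 (Homo sapiens), read by cAMP accumulation (on this read-out lower numbers stand for smaller maximal responses and higher numbers for larger maximal responses), where compound 3 reaches 72%. Its nearest neighbour is compound 1 `CC(=O)N1CCN(CCN2CCC(CNC(=O)c3cccc4[nH]c(C(C)C)nc34)CC2)CC1`, which in this assay gives 76%. Compound 2 `CS(=O)(=O)N1CCN(CC(O)CN2CCC(NC(=O)c3cccc4[nH]cnc34)CC2)CC1` lies far lower: in this assay compound 2 gives 7%. The change to compound 4 `CC(C)c1nc2c(C(=O)NCC3CCN(CCN4CCN(S(C)(=O)=O)CC4)CC3)cccc2[nH]1` is methylsulfonyl in place of methoxycarbonyl on an amine nitrogen in a ring. Within the data shown here, only one measured step bears on it: a number 4 percentage points lower from compound 1 to compound 3 (within the scatter), another exchange of the group on that ring nitrogen, which shifted the response little. Compound 2 also carries a methylsulfonyl group, but it differs from compound 3 in several other places, so its low number cannot be tied to that group alone. The step to compound 4 is therefore expected to be small, a number 6 percentage points lower from compound 3 to compound 4 (within the scatter). Compound 4 is estimated at 66%, with a range from 40% to 85%.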

Compound 4, intrinsic activity: the largest response reached, in percent of the reference agonist's: 64%
Estimate against measurement, compound 4: 2 percentage points above, within the range that was stated.
By their numbers in this assay, from the lowest: compound 2; then compounds 4, 3 and 1 (each within the scatter of the next, the first and the last beyond it).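

In this assay, methylsulfonyl on this amine nitrogen in a ring keeps most of the response: in place of methoxycarbonyl it gives a number 8 percentage points lower from compound 3 to compound 4 (within the scatter). Among these compounds, in place of acetyl it gives a number 12 percentage points lower from compound 1 to compound 4 (beyond the scatter), the first step at this nitrogen to pass the scatter, though it is only a modest one. Nothing measured here explains either step. As far as these compounds go, it remains open how the response would change with an unsubstituted ring nitrogen, a simple methyl group or a longer ethylsulfonyl chain at this position.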